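Compound 1 to compound 3: phenyl for pyridin-2-yl

The source may hold more compounds than are shown below. What is called first, only, known or untested is meant among the compounds shown, and "the series" means these compounds.

For the measured compounds named here, in a functional assay on HepG2 cells (Homo sapiens) for antiproliferative activity, read by MTT assay, with a stated time of 48 h (a lower number here means a stronger inhibitor, a higher number a weaker inhibitor), compound 1 (`O=C(/C=C/c1ccccn1)c1nc2ccccc2[nH]1`) gives 340 nM as the only actual number so far. Compound 2 (`O=C(/C=C/c1cccc(Cl)c1)c1nc2ccccc2o1`) gives > 100000 nM in this assay as a limit and not a number. Compound 3 (`O=C(/C=C/c1ccccc1)c1nc2ccccc2[nH]1`) is still unmeasured and carries phenyl in place of pyridin-2-yl on a double-bonded chain carbon bound to a double-bonded chain carbon. Going by the values given here, no measured step bears on this change. A modest weakening is expected in this assay and is estimated as a 1.8-fold higher number from compound 1 to compound 3 (0.25 log units; within the scatter) for now. The expected value for compound 3 is 600 nM (120 nM to 3000 nM).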

Compound 3, half-maximal inhibitory concentration: 6300 nM
The estimate for compound 3 lay 11-fold (1.02 log units) below the measured number, outside the stated range (above it).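

In this assay, exchanging pyridin-2-yl for phenyl gives a 19-fold higher number from compound 1 to compound 3 (1.27 log units; beyond the scatter). This position is therefore sensitive to a single atom: both groups are six-membered aromatic rings of 6 heavy atoms, and the ring nitrogen with its hydrogen-bond acceptor is what leaves. Nothing shown gives a cause for this step.

Open, going by these compounds, is how pyridin-3-yl, pyridin-4-yl or pyrimidin-2-yl would read on this double-bonded chain carbon, and so whether the ring nitrogen's presence alone suffices. Also open, on these data alone, is whether the step holds on a core other than that of compound 1.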